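From acetyl to cyclopropyl(methyl)carbamoyl: an expected solubility step

This account rests on a few compounds, and the source may have more. Where it says the series, first, only, none or still open, it means among the compounds named here.

Compound 2 `CC(=O)c1cc(-c2ccc(S(N)(=O)=O)cc2)n(-c2ccc(Cl)cc2)n1` stands highest among the three compounds measured in a physicochemical assay for solubility, read by HPLC, in phosphate buffer, measured as kinetic solubility, at pH 7.4 (on this read-out higher numbers stand for higher solubility and lower numbers for lower solubility), where compound 2 gives 86800 nM. Compound 3 `CCC(=O)c1cc(-c2ccc(S(N)(=O)=O)cc2)n(-c2ccc(C(F)(F)F)cc2)n1` gives 7500 nM and compound 1 `CCC(=O)c1cc(-c2ccc(Cl)cc2)n(-c2ccc(S(=O)(=O)N(C)C)cc2)c1C` gives 1200 nM; both gaps to compound 2 lie beyond the scatter. Compound 4 `CN(C(=O)c1cc(-c2ccc(S(N)(=O)=O)cc2)n(-c2ccc(Cl)cc2)n1)C1CC1` has not been measured. It differs from compound 2 in one place: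

cyclopropyl(methyl)amino in place of methyl on a carbonyl carbon

Within the data shown here, no measured pair shows this same change, so its effect can only be estimated. In this assay the change is expected to lower the number by a modest step, a 2.5-fold lower number from compound 2 to compound 4 (0.39 log units; beyond the scatter), which may not clear the scatter. Compound 4 is therefore estimated in this assay at 35000 nM, with a range from 10000 nM to 120000 nM.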

Compound 4, solubility: 99600 nM
The estimate for compound 4 lay 2.8-fold (0.45 log units) below the measured number; the range from low to high includes it.
By their numbers in this assay, from the lowest: compound 1; then compound 3; then compounds 2 and 4 (each within the scatter of the next).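

Replacing methyl with cyclopropyl(methyl)amino on a carbonyl carbon gives a 1.1-fold higher number from compound 2 to compound 4 (0.06 log units; within the scatter) in this assay and so shows that this position takes the larger group, with its three-membered ring, without a step beyond the scatter. The earlier compounds shown here offered no reading of any change here, as no pair of them differed in one place alone. Nothing available explains this result.

The compounds shown leave open what a longer chain, a dimethylamino group or a hydroxyl group on this carbonyl carbon would give. From the compounds shown here alone, whether the same change gives a similar step on the core of compound 3 also stays open.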